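A few compounds are considered here, and "the series" means these few. Any claim that something is new, unique, unknown or untested is made for them only; others in the source may bear on it.

Compound 3 `C=CCn1c(=O)/c(=C\c2ccc(C)cc2)[nH]c(=O)/c1=C\c1ccccc1OC` carries a 4-methylphenyl on the double-bonded chain carbon bound to an aromatic carbon of the shared core. In a functional assay on HeLa cells (Homo sapiens) for cytotoxicity, read by CCK-8 assay, with a stated time of 72 h (a higher number here means a weaker inhibitor, a lower number a stronger inhibitor), compound 3 returns "not active" (no number reported), so no single number stands for it, and its place among the measured compounds cannot be fixed. The reported numbers come from compound 1 `C=CCn1c(=O)/c(=C\c2ccccc2Cl)[nH]c(=O)/c1=C\c1ccccc1OC`, which in this assay gives 5100 nM, and from compound 2 `C=CCn1c(=O)/c(=C\c2cccc(Cl)c2Cl)[nH]c(=O)/c1=C\c1ccccc1OC`, which gives 1600 nM. Compound 4 `C=CCn1c(=O)/c(=C\c2cccc(C)c2)[nH]c(=O)/c1=C\c1ccccc1OC` differs from compound 3 only in that (3-methylphenyl in place of 4-methylphenyl on a double-bonded chain carbon bound to an aromatic carbon). For the measured compounds named here, no measured step mirrors this move of a methyl from one position of the ring to another. Going by the values given here, the only step on record, a 3.2-fold lower number from compound 1 to compound 2 (0.50 log units; beyond the scatter), concerns added chloro and is modest, so it bears on this change only loosely, and compound 3 offers no number to step from. Compound 4 is therefore expected to be weak, with an estimate in this assay of 8000 nM, ranging from 2000 nM to 30000 nM.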

Compound 4, half-maximal inhibitory concentration: 19300 nM
Compound 4: the middle estimate sits 2.4-fold (0.38 log units) below what was measured; the range from low to high includes it.
By their numbers in this assay, from the lowest: compound 2; then compound 1; then compound 4.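

With compound 4, a methyl-bearing ring on the double-bonded chain carbon bound to an aromatic carbon gains its first number: in this assay the change to 3-methylphenyl gives a 3.8-fold higher number from compound 1 to compound 4 (0.58 log units; beyond the scatter) and a 12-fold higher number from compound 2 to compound 4 (1.08 log units; beyond the scatter) and so leaves compound 4 weaker than both chlorinated compounds. Compound 3 returned no number, so the move from 4-methylphenyl to 3-methylphenyl cannot be read as a step, and all that can be said is that compound 4 has a number where compound 3 has none. No available evidence gives a reason for these differences.

The compounds shown leave open how a ring bearing an amine or a carboxylic acid would read at this place. They also leave open whether a ring bearing trifluoromethyl or a nitrile would stand nearer to compound 2 or to compound 4.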